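Swapping the Aryl Group on a Triazole Nitrogen

A few compounds are considered here, and "the series" means these few. Any claim that something is new, unique, unknown or untested is made for them only; others in the source may bear on it.

Compound 1, `CCc1ccccc1-n1nncc1CN1C(=O)C2(C(C#N)=C(N)Oc3c(N)cc4nc5ccccc5nc4c32)c2ccccc21`: 17900 nM
Compound 2, `CCc1cccc(C)c1-n1nncc1CN1C(=O)C2(C(C#N)=C(N)Oc3c(N)cc4nc5ccccc5nc4c32)c2ccccc21`: > 50000 nM

In a functional assay on HepG2 cells (Homo sapiens) for antiproliferative activity, read by MTT assay, with a stated time of 48 h (a lower number here means a stronger inhibitor, a higher number a weaker inhibitor), compound 1 gives 17900 nM. Compound 2 gives only a limit of the assay, > 50000 nM, so its exact value is not known, as the limit itself shows (the limit of > 50000 nM in this assay, at which 1 of the 2 values shown sits). Going by the values given here, the single measured step, an at least 2.7-fold higher number from compound 1 to compound 2 (0.44 log units; beyond the scatter), is the only guide: adding a methyl on an aromatic carbon of the aryl group made the inhibitor weaker.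

Compound 3, `Cc1ccc(C)c(-n2nncc2CN2C(=O)C3(C(C#N)=C(N)Oc4c(N)cc5nc6ccccc6nc5c43)c3ccccc32)c1`, differs from compound 2 by 2,5-dimethylphenyl in place of 2-ethyl-6-methylphenyl on an aromatic nitrogen. The step from compound 2 to compound 3 is not the same as the measured one, so it can only be read loosely; the new aryl group carries two methyls rather than an ethyl and a methyl, which keeps the compound near the weak end seen so far. Compound 3 is therefore expected to stay weak, with an estimated step of an at least 1.4-fold lower number from compound 2 to compound 3 (0.15 log units; that floor lies within the scatter). Compound 3 is estimated at 35000 nM, within a range from 12000 nM to 100000 nM.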

Compound 3, half-maximal inhibitory concentration: > 50000 nM
Compound 3 ended at the assay's limit; the forecaster's own chance of this, stated with the estimate: 40%; middle value at least 1.4-fold (0.15 log units) from the limit.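

In this assay, compound 3 gives only a limit of the assay, > 50000 nM. The change to 2,5-dimethylphenyl in place of 2-ethylphenyl on the aromatic nitrogen is an at least 2.7-fold higher number from compound 1 to compound 3 (0.44 log units; beyond the scatter), so a second replacement of the aryl group of compound 1, and not only 2-ethyl-6-methylphenyl, leaves a weaker inhibitor. The step between compound 2 and compound 3 cannot be read, because both compounds stand at the same limit: the limit of > 50000 nM in this assay, at which 2 of the 3 values shown sit.

Going by these compounds, how much weaker compound 2 and compound 3 really are than compound 1 stays unknown, and so does any order between those two. On these data alone, it also remains open whether a plain phenyl group, or an aryl group carrying an amine or a carboxylic acid, would give a lower number than compound 1.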